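The compounds below may be only part of what the source reports. "The series", "measured", "known", "first", "only" and "open" are said of these compounds alone.

In a functional assay on MCF-10A cells (Homo sapiens) for antiproliferative activity, with a stated time of 48 h (a higher number here means that more compound is needed for the effect, a lower number that less compound is needed), compound 1 (`COc1ccc2nc(C)cc(NCc3ccccc3)c2c1`) gives 28600 nM and compound 2 (`COc1ccc2nc(C)cc(NCc3ccccc3F)c2c1`) gives 17000 nM while compound 3 (`COc1ccc2nc(C)cc(NCc3ccc(F)cc3F)c2c1`) gives 15000 nM on the same read-out. These numbers sit close together, and compound 2 stands within the scatter of both other compounds. Compound 4 (`COc1ccc2nc(C)cc(NCc3ccccc3OC)c2c1`) differs from compound 2 by a single change, methoxy in place of fluoro on an aromatic carbon.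

Going by the values given here, two measured steps bear on this change, and both put fluoro in place of hydrogen on an aromatic carbon. The first is a 1.7-fold lower number from compound 1 to compound 2 (0.23 log units; within the scatter) and the second is a 1.1-fold lower number from compound 2 to compound 3 (0.05 log units; within the scatter) in the same series. Both stayed within the scatter, which suggests little movement for these two swaps. Neither step brings in methoxy, however, so they offer only indirect guidance. With so little to go on, no step beyond the scatter is expected in this assay and no direction is favoured. Estimated in size, a 1.2-fold higher number from compound 2 to compound 4 (0.07 log units; within the scatter) would be the expected step. The estimate for compound 4 is 20000 nM with an expected range from 9000 nM to 45000 nM in this series.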

Compound 4, half-maximal effective concentration: 29500 nM
Compound 4: the middle estimate sits 1.5-fold (0.17 log units) below what was measured, and the stated range covers the measured number.
By their numbers in this assay, from the lowest: compounds 3, 2, 1 and 4 (each within the scatter of the next).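

In this assay, putting methoxy in place of fluoro on this aromatic carbon, ortho to a large group, gives a 1.7-fold higher number from compound 2 to compound 4 (0.24 log units; within the scatter), so this swap, which brings in 2 heavy atoms and 1 hydrogen-bond acceptor where a single fluorine stood, stays inside the usual spread of repeat measurements. Set against plain hydrogen at the same place, methoxy gives a 1.0-fold higher number from compound 1 to compound 4 (0.01 log units; within the scatter), which means that the series now holds a group larger than fluoro at this position and the number still shows no change that can be told from scatter. Nothing measured alongside these numbers offers an account of this result.

Open, as far as these compounds go, is whether a group of a different kind on the same carbon, such as an amine, a carboxylic acid or a longer chain like ethoxy, would produce a step beyond the scatter. The compounds shown also leave open whether methoxy would give the same result on another carbon of this ring, since every methoxy comparison here concerns this one place.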